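The source may hold more compounds than are shown below. What is called first, only, known or untested is meant among the compounds shown, and "the series" means these compounds.

Working notes on the series. All three measured compounds share one core and differ only at the amide-type nitrogen. Compound 3 `Cc1cccc(NC(=O)c2c(O)c3cccnc3n(-c3ccccc3)c2=O)c1` stands highest of the three in a functional assay on the whole organism for inhibition, with Rattus norvegicus as the target, read by paw edema, at a dose of 100 mg/kg by the oral route; on this read-out higher numbers stand for more inhibition at the one dose given (going by the name of the read-out) and lower numbers for less inhibition; compound 3 gives 14.2%. Compound 2 `O=C(NCc1ccccc1)c1c(O)c2cccnc2n(-c2ccccc2)c1=O` is nearest: in this assay compound 2 gives 1.6%, and a number 12.6 percentage points higher from compound 2 to compound 3 (beyond the scatter) lies beyond the scatter. Compound 1 `O=C(Nc1ccccn1)c1c(O)c2cccnc2n(-c2ccccc2)c1=O` is furthest: in this assay compound 1 gives -13.5%, with a number 27.7 percentage points higher from compound 1 to compound 3 (beyond the scatter) and a number 15.1 percentage points higher from compound 1 to compound 2 (beyond the scatter) both beyond the scatter.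

Compound 4 `O=C(NCc1cccnc1)c1c(O)c2cccnc2n(-c2ccccc2)c1=O` is not yet measured. It differs from compound 3 by the exchange ((pyridin-3-yl)methyl in place of 3-methylphenyl on an amide-type nitrogen). For the measured compounds named here, two measured steps bear on it. The ring nitrogen of the entering group recalls compound 1, which carries pyridin-2-yl and gives the lowest number of the set; the methylene recalls compound 2, which carries benzyl and sits below compound 3 by a number 12.6 percentage points higher from compound 2 to compound 3 (beyond the scatter). Both features are tied to lower numbers than the 3-methylphenyl of compound 3, so a fall beyond the scatter is expected in this assay, at least as large as the reverse of a number 12.6 percentage points higher from compound 2 to compound 3 (beyond the scatter). Compound 4 is therefore estimated at 0%, within -15% to 14%. The expected step is a number 14.2 percentage points lower from compound 3 to compound 4 (beyond the scatter).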

Compound 4, a percentage reported as inhibition, in the whole organism at one dose (the size of the read-out at that dose, not a potency): 25.5%
The estimate for compound 4 lay 25.5 percentage points below the measured number; the measured number lies above the stated range.
By their numbers in this assay, from the lowest: compound 1; then compound 2; then compound 3; then compound 4.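

At the amide-type nitrogen, (pyridin-3-yl)methyl takes the series above the 3-methylphenyl of compound 3 in this read-out (this assay), with the exchange giving (a number 11.3 percentage points higher from compound 3 to compound 4 (beyond the scatter)), so a methylene on that nitrogen and a ring nitrogen in the entering group do not by themselves go with low numbers. For the compounds shown here, with the methylene kept, pyridin-3-yl in place of phenyl gives (a number 23.9 percentage points higher from compound 2 to compound 4 (beyond the scatter)), the first measured exchange made on the saturated chain carbon rather than on the amide-type nitrogen, while the exchange from pyridin-2-yl gives (a number 39 percentage points higher from compound 1 to compound 4 (beyond the scatter)), so the low number of compound 1 cannot be read as belonging to every pyridine ring. Nothing measured on these compounds beyond this read-out bears on the result.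

The compounds shown leave open whether the gain depends on where the ring nitrogen sits, as (pyridin-2-yl)methyl or (pyridin-4-yl)methyl would show, and whether pyridin-3-yl needs the methylene at all or would hold with a longer chain such as 2-(pyridin-3-yl)ethyl. They also leave open how these numbers would change at other doses, since each compound is read at a single dose.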